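Replacing the tetrazolylsulfanyl arm with a methylpiperazine

The source may report more compounds than this note shows. Statements on the series, on what has been measured and on what is new or still open speak of the compounds shown alone.

Compound 3 `Cn1nnnc1SCC(=O)Nc1ccc(-c2nc(-c3ccccc3)c(-c3ccccc3)n2C)cc1` stands highest of the three measured compounds in a functional assay on HT-29 cells (Homo sapiens) for cytotoxicity, read by MTT assay, with a stated time of 24 h, tested at 16 ug/mL (on this read-out higher numbers stand for a stronger effect at the one concentration tested and lower numbers for a weaker effect), where compound 3 gives 72.5%. Compound 2 `Cn1cnnc1SCC(=O)Nc1ccc(-c2nc(-c3ccccc3)c(-c3ccccc3)n2C)cc1` gives 59.1% and compound 1 `Cc1ccc2oc(SCC(=O)Nc3ccc(-c4nc(-c5ccccc5)c(-c5ccccc5)n4C)cc3)nc2c1` gives 37.7%; the rise a number 34.8 percentage points higher from compound 1 to compound 3 (beyond the scatter) is large, while a number 21.4 percentage points higher from compound 1 to compound 2 (beyond the scatter) and a number 13.4 percentage points higher from compound 2 to compound 3 (beyond the scatter) are modest. Compound 4 `CN1CCN(CC(=O)Nc2ccc(-c3nc(-c4ccccc4)c(-c4ccccc4)n3C)cc2)CC1` differs from compound 3 in that (4-methylpiperazin-1-yl in place of (1-methyl-1H-tetrazol-5-yl)sulfanyl on a saturated chain carbon bound to a carbonyl carbon). Going by the values given here, every measured step only exchanges one aromatic heterocycle for another on the same sulfur; none removes the sulfur or introduces a six-membered non-aromatic ring, so no step speaks directly to this change. The scatter between the three heterocycles already spans a wide range, and compound 3 sits at the top of it, so the estimate for compound 4 is a lower number, with an expected step of a number 24.5 percentage points lower from compound 3 to compound 4 (beyond the scatter) in this assay. The expected value for compound 4 is 48%, within 22% and 74%.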

Compound 4, a percentage reported as activity, at one concentration (the size of the read-out at that concentration, not a potency): 33.7%
Compound 4: the middle estimate sits 14.3 percentage points above what was measured, within the range that was stated.
By their numbers in this assay, from the lowest: compounds 4 and 1 (each within the scatter of the next); then compound 2; then compound 3.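

In this assay, the 4-methylpiperazin-1-yl group on the saturated chain carbon bound to a carbonyl carbon gives a number well under the two small azole arms: the exchange gives a number 38.8 percentage points lower from compound 3 to compound 4 (beyond the scatter) and a number 25.4 percentage points lower from compound 2 to compound 4 (beyond the scatter). The same group cannot be told apart from the benzoxazolyl arm, with a number 4 percentage points lower from compound 1 to compound 4 (within the scatter), so this position accepts a change away from the sulfur but, among the four compounds, high readings occur only with the tetrazolyl and triazolyl sulfanyl arms. No measurement available here explains these differences.

The exchange removes the sulfur and the aromatic ring together, so the compounds shown do not separate the two. A morpholine ring or an open-chain dimethylamino group on the same carbon, or a tetrazolyl ring joined through a methylene in place of the sulfur, would bear on that question.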